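The compounds below may be only part of what the source reports. "The series", "measured", "known", "first", "only" and "open" are said of these compounds alone.

Within the data shown here, compound 1 `N#Cc1cnc(NCc2cnccc2C(F)(F)F)cc1NC[C@H]1C[C@H](O)C1` is the weakest of the three measured members of this set: in an assay on isolated protein for inhibition of protein kinase C theta type (Homo sapiens), read by TR-FRET, with a stated time of 2 h (a lower number here means a stronger inhibitor, a higher number a weaker inhibitor), compound 1 gives 700 nM, the highest of the three numbers. Compound 2 `N#Cc1cnc(NCc2ccccc2C(F)(F)F)cc1N[C@H]1CC[C@@H](O)CC1` gives 140 nM in this assay, and compound 3 `CC(C)(F)c1ncncc1CNc1cc(N[C@H]2CC[C@@H](O)CC2)c(C#N)cn1` gives 32 nM in this assay; both sit beyond the scatter from compound 1, and both carry a six-membered non-aromatic ring of carbon only directly on the nitrogen on the aromatic ring, where compound 1 has the (3-hydroxycyclobutyl)methyl.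

Compound 4 `CC1(C)C[C@H](Nc2cc(NCc3cnccc3C(F)(F)F)ncc2C#N)CC[C@H]1O` has not been measured. It differs from compound 1 in one place: 4-hydroxy-3,3-dimethylcyclohexyl in place of (3-hydroxycyclobutyl)methyl on a nitrogen on an aromatic ring. The rest of the molecule, including the trifluoromethyl-bearing ring on the other nitrogen, is kept from compound 1.

A step downward, beyond the scatter, is expected in this assay from compound 1 to compound 4, because compound 2 gives 140 nM with a six-membered non-aromatic ring of carbon only in the same place. Compound 4 is estimated at 180 nM, range 60 nM to 500 nM, an expected step of a 3.9-fold lower number from compound 1 to compound 4 (0.59 log units; beyond the scatter).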

Compound 4, half-maximal inhibitory concentration: 100 nM
Compound 4: the middle estimate sits 1.8-fold (0.26 log units) above what was measured; the range from low to high includes it.
By their numbers in this assay, from the lowest: compound 3; then compounds 4 and 2 (each within the scatter of the next); then compound 1.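

In this assay, 4-hydroxy-3,3-dimethylcyclohexyl in place of (3-hydroxycyclobutyl)methyl on a nitrogen on an aromatic ring gives a 7.0-fold lower number from compound 1 to compound 4 (0.85 log units; beyond the scatter). Among these compounds, this is the first reading of this position with the rest of the molecule held fixed, and it shows that the substituent on this nitrogen alone moves the number beyond the scatter. Nothing on hand accounts for the step.

The change alters the ring size, the link to the nitrogen and the two methyl groups at once, so the compounds shown leave open how much of the step belongs to each. Also open, as far as these compounds go, is whether an amine or a carboxylic acid could stand in place of the hydroxy group on the cyclohexyl ring.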